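The compounds below may be only part of what the source reports. "The series", "measured", "known", "first", "only" and "open" are said of these compounds alone.

Measured so far:
- compound 1, `CC(C)(N)CN(C(=O)[C@@H]1C[C@H]1c1ccccc1)c1ccc(-c2ccccc2)cc1`: 1.4 nM
- compound 2, `CC[C@H](C)[C@H](N)CN(C(=O)[C@@H]1C[C@H]1c1cccc(OC)c1)c1ccc(-c2ccccc2)cc1`: 3000 nM

In a functional assay for agonist activity at G protein-coupled receptor 88 (Homo sapiens), read by HTRF and cAMP accumulation (on this read-out higher numbers stand for an effect only at larger amounts of compound and lower numbers for an effect already at smaller amounts), compound 1 gives 1.4 nM, while compound 2 gives 3000 nM. Of the two numbers, compound 2 has the higher one, and its gap to compound 1 lies far beyond the scatter. Compound 2 and compound 1 differ in more than one place, so their two values alone cannot be split into single contributions.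

Compound 3, `CC[C@H](C)[C@H](N)CN(C(=O)[C@@H]1C[C@H]1c1cccnc1)c1ccc(-c2ccccc2)cc1`, is not yet measured. It differs from compound 2 in one place: pyridin-3-yl in place of 3-methoxyphenyl on a saturated ring carbon. Among the measured compounds shown here, no pair of measured compounds shows what this change does, so the expected step from compound 2 to compound 3 in this assay rests on the structural change alone. A modest rise is expected, because compound 2 already stands at 3000 nM and the change is small, but no direction can be ruled out; the expected step is a 1.3-fold higher number from compound 2 to compound 3 (0.12 log units; within the scatter). Compound 3 is expected to give about 4000 nM, within a range from 1000 nM to 20000 nM.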

Compound 3, half-maximal effective concentration: 1500 nM
For compound 3 the middle estimate is 2.7-fold (0.43 log units) above the measured one; the measured number falls inside the stated range.
By their numbers in this assay, from the lowest: compound 1; then compounds 3 and 2 (each within the scatter of the next).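

Putting pyridin-3-yl in place of 3-methoxyphenyl on a saturated ring carbon of the three-membered ring gives a 2.0-fold lower number from compound 2 to compound 3 (0.30 log units; within the scatter) in this assay. Among the compounds shown here, this is the first comparison here that isolates a single change, and it shows that, on this core, the position accepts an aromatic ring with a ring nitrogen in place of a carbon-only ring carrying methoxy, with no change that can be told from repeat variation. No measurement beyond these numbers bears on why the swap leaves the result within that variation.

As far as these compounds go, whether pyridin-4-yl or pyrimidin-5-yl would behave the same way at this position remains open. Also open, from the compounds shown here alone, is whether the same swap would be as well accepted on the core of compound 1, which gives 1.4 nM.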